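The source may report more compounds than this note shows. Statements on the series, on what has been measured and on what is new or still open speak of the compounds shown alone.

Working notes on the series. For the measured compounds named here, only one compound so far gives a number in a functional assay on HEK293 cells for agonist activity at Toll-like receptor 8 (Homo sapiens), read by reporter gene assay; on this read-out lower numbers stand for an effect already at smaller amounts and higher numbers for an effect only at larger amounts of compound: compound 1 `Cc1ncc(CO)c2c(Nc3ccccc3)c(NCc3ccccc3)oc12`, for which compound 1 gives 1680 nM. Compound 2 `CCOC(=O)CNc1oc2c(C)ncc(CO)c2c1Nc1ccccn1` stands apart from that: in this assay compound 2 gives "not active" (no number reported), so no number exists for it. Compound 3 `Cc1ncc(CO)c2c(Nc3cnccn3)c(NC(C)(C)C)oc12` is the other entry without a number; in this assay compound 3 gives "not active" (no number reported). Going by the values given here, with two of three compounds reporting no value, no step between measured compounds can be drawn, and nothing can be said about the size of any gap among them.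

Compound 4 `Cc1ncc(CO)c2c(Nc3ccccn3)c(NC3CCCCC3)oc12` has not been measured. Set against compound 2 it carries cyclohexyl in place of (ethoxycarbonyl)methyl on a nitrogen on an aromatic ring. Among the compounds with values here, no step of this kind is known anywhere, so its size and direction in this assay cannot be read from the data; the only anchor is that compound 1 gives a number while compound 2 and compound 3 do not. Compound 4 is therefore expected to fall near 2000 nM, with a wide expected range from 300 nM to 20000 nM, and a real chance that no number is reported.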

Compound 4, half-maximal effective concentration: 6930 nM
Beside the measured number, compound 4's estimate is 3.5-fold (0.54 log units) below it; the range from low to high includes it.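

In this assay, for the compounds shown here, compound 4 gives 6930 nM while compound 2 gives "not active" (no number reported), so no step between them can be read. On these data alone, whether the change from (ethoxycarbonyl)methyl to cyclohexyl alone separates a number from no number stays open. No measured evidence bears on this result.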